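Swapping acetyl for dimethylamino on the outer phenyl ring

This account rests on a few compounds, and the source may have more. Where it says the series, first, only, none or still open, it means among the compounds named here.

Compound 1 `COc1cc(C)cc(-c2c(-c3ccnc(-c4ccc(C(C)=O)cc4)c3)cnn2CC#N)c1` gives 43%.
Compound 2 `COc1cc(C)cc(-c2nn(CC#N)cc2-c2ccc(-c3cccc(C(C)=O)c3)nc2)c1` gives -1%.

Of the compounds shown here, two have been measured in a functional assay on Malme-3M cells (Homo sapiens) for cytotoxicity, read by sulforhodamine B assay, with a stated time of 48 h, tested at 10 uM; on this read-out higher numbers stand for a weaker effect at the one concentration tested and lower numbers for a stronger effect. Compound 1 gives 43% in this assay and stands highest of the two numbers; the nearest is compound 2, whose value of -1% lies lower by a gap beyond the scatter. The two share a core, and the difference between them is not a single change, so only what the two values show is said of the pair.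

Compound 3 `COc1cc(C)cc(-c2c(-c3ccnc(-c4ccc(N(C)C)cc4)c3)cnn2CC#N)c1` has not yet been measured in this assay. It differs from compound 1 in one place: dimethylamino in place of acetyl on an aromatic carbon. The acetyl of compound 1 gives way to dimethylamino at the same aromatic carbon of the six-membered aromatic ring of carbon only, para to a large group. For the measured compounds named here, no pair of measured compounds shows this change, so the size of its step in this assay is unknown from the data.

Compound 3 is expected to give a somewhat lower number than compound 1, a step of a number 8 percentage points lower from compound 1 to compound 3 (within the scatter) in this assay, but the step may well fall within the scatter. The estimate for compound 3 is 35%, with a range from 5% to 65%.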

Compound 3, a percentage reported as activity, at one concentration (the size of the read-out at that concentration, not a potency): 13%
Compound 3: the middle estimate sits 22 percentage points above what was measured; the range from low to high includes it.
By their numbers in this assay, from the lowest: compound 2; then compound 3; then compound 1.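

In this assay, putting dimethylamino in place of acetyl on this aromatic carbon, para to a large group, gives a number 30 percentage points lower from compound 1 to compound 3 (beyond the scatter) and so a stronger effect at the one concentration tested. For the compounds shown here, this is the first change in a single place that can be read, since compound 1 and compound 2 differ in more than one place, and it shows that the read-out responds to the group held at this position of the core of compound 1. The two groups match in heavy-atom count, in hydrogen-bond donors and acceptors and in net charge, so these counts do not separate them, and no measurement at hand explains the difference between the two groups.

The compounds shown cover only these two groups at this position, so it remains open how a primary amine, a methylamino group, a carboxylic acid or a longer chain would read there. As far as these compounds go, it also remains open whether dimethylamino in place of acetyl would give a step of similar size on the core of compound 2.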